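A few compounds are considered here, and "the series" means these few. Any claim that something is new, unique, unknown or untested is made for them only; others in the source may bear on it.

Measured so far:
- compound 1, `CC(C)CC(=O)Oc1ccc2oc(/C=C/[S+](C)[O-])cc(=O)c2c1`: 6100 nM
- compound 2, `COc1ccc2c(=O)cc(/C=C/[S+](C)[O-])oc2c1`: 7800 nM

Both were tested in a functional assay on DLD-1 cells (Homo sapiens) for cytotoxicity, with a stated time of 48 h; on this read-out lower numbers stand for stronger inhibition and higher numbers for weaker inhibition. Compound 1 holds the smaller of the two numbers, but its gap to compound 2 lies within the scatter, so the two compounds cannot be told apart on these values.

Compound 3, `CC(C)C(=O)Oc1ccc2oc(/C=C/[S+](C)[O-])cc(=O)c2c1`, has not yet been measured. It differs from compound 1 in one place: isopropyl in place of isobutyl on a carbonyl carbon. A shorter branched chain enters at the ester carbonyl, with no change in rings, donors, acceptors or charge. Among the compounds with values here, no comparable step between measured compounds is available, so there is nothing to anchor a direction. Given how close the two measured compounds lie, the step from compound 1 to compound 3 is expected to be small, a 1.1-fold higher number from compound 1 to compound 3 (0.06 log units; within the scatter), and not beyond the scatter either way. Compound 3 is therefore expected to give about 7000 nM, with a likely range from 3500 nM to 14000 nM.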

Compound 3, half-maximal inhibitory concentration: 9100 nM
Compound 3: the middle estimate sits 1.3-fold (0.11 log units) below what was measured, and the stated range covers the measured number.
By their numbers in this assay, from the lowest: compounds 1, 2 and 3 (each within the scatter of the next).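

In this assay, within the data shown here, the first one-place comparison in this set, isopropyl in place of isobutyl on a carbonyl carbon gives a 1.5-fold higher number from compound 1 to compound 3 (0.17 log units; within the scatter) and so stays inside the normal variation between repeat measurements. At this position, these two small branched chains therefore cannot be told apart, which suggests that this assay does not distinguish this particular change in chain. No independent measurement is available to explain this result or to describe what either chain contributes.

Going by these compounds, whether a longer chain such as octyl, or a chain carrying an amine or a carboxylic acid, would shift the value beyond that variation remains open. The compounds shown also leave open what would happen if an amide replaced the ester link.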